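A few compounds are considered here, and "the series" means these few. Any claim that something is new, unique, unknown or untested is made for them only; others in the source may bear on it.

Values in a functional assay on U-251 cells (Homo sapiens) for antiproliferative activity, read by MTT assay, with a stated time of 24 h; on this read-out lower numbers stand for stronger inhibition and higher numbers for weaker inhibition:

- compound 1 `C=CCOc1ccc2c(=O)c(-c3cc(OC)c(OC)cc3OC)coc2c1`: 5900 nM
- compound 2 `C#CCOc1ccc2c(=O)c(-c3cc(OC)c(OC)cc3OC)coc2c1`: 6450 nM

These two compounds cannot be told apart. Compound 2, at 6450 nM, stands level with compound 1 within the scatter, so neither marks an end of a range. The next compound is compound 3 `COc1cc(OC)c(-c2coc3cc(OCC(=O)c4cccc(C(F)(F)F)c4)ccc3c2=O)cc1OC`, which keeps the shared core and changes only the group on the saturated chain carbon bound to an oxygen on an aromatic ring: (3-(trifluoromethyl)phenyl)carbonyl in place of ethynyl on a saturated chain carbon bound to an oxygen on an aromatic ring. In words, (3-(trifluoromethyl)phenyl)carbonyl comes in place of ethynyl.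

Going by the values given here, only one measured step bears on this place, a 1.1-fold higher number from compound 1 to compound 2 (0.04 log units; within the scatter). It exchanged vinyl for ethynyl and stayed within the scatter. Among the compounds with values here, that step says little about the far larger group entering here, and no measured compound carries an aromatic ring at this place. The data therefore give no firm direction, and no change well beyond the scatter is expected in this assay. The expected step, a 1.4-fold lower number from compound 2 to compound 3 (0.16 log units; within the scatter), is a modest one with wide uncertainty. For compound 3 the estimate is 4500 nM, with an expected range from 1500 nM to 13000 nM.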

Compound 3, half-maximal inhibitory concentration: > 10000 nM
Compound 3 was reported as a limit; the forecaster's own chance of this, stated with the estimate: 5%; middle value at least 2.2-fold (0.34 log units) away from the limit.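

In this assay compound 3 is reported only as a limit, > 10000 nM. Measured against the small unsaturated groups, the replacement gives an at least 1.5-fold higher number from compound 2 to compound 3 (0.19 log units; that floor lies within the scatter) and an at least 1.6-fold higher number from compound 1 to compound 3 (0.22 log units; that floor lies within the scatter), so a far larger group at this saturated chain carbon, bringing an aromatic ring and a carbonyl, yields no lower number than either ethynyl or vinyl, which the earlier exchange between those two small groups could not show. Both floors lie within the scatter, so the result does not establish a real rise in the number, and its true size cannot be read, which confines the finding to the absence of any gain at this place: the limit of > 10000 nM in this assay, at which 1 of the 3 values shown sits.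

The compounds shown leave open whether the carbonyl or the 3-(trifluoromethyl)phenyl ring governs this outcome, since the two enter together as one group and their contributions cannot be separated here. They also leave open how a plain phenyl group, a longer chain ending in an amine or a carboxylic acid at this place would read in this assay.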